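The compounds below may be only part of what the source reports. "The series", "measured", "known", "first", "only" and "open" are said of these compounds alone.

Measured so far in a functional assay on MOLT-4 cells (Homo sapiens) for antiproliferative activity, read by CCK-8 assay, with a stated time of 72 h; on this read-out higher numbers stand for weaker inhibition and lower numbers for stronger inhibition:
- compound 1 `Cc1cc(Nc2cc(N3CCN(C)CC3)nc(Nc3ccc([N+](=O)[O-])cc3)n2)n[nH]1`: 18.1 nM
- compound 2 `Cc1cc(Nc2cc(N3CCN(C)CC3)nc(Nc3ccc(Cl)cc3)n2)n[nH]1`: 53.1 nM
- compound 3 `COc1cccc(Nc2nc(Nc3cc(C)[nH]n3)cc(N3CCN(C)CC3)n2)c1`: 192 nM

Compound 3 has the highest number of the three, and the closest step to it is a 3.6-fold higher number from compound 2 to compound 3 (0.56 log units; beyond the scatter). The widest is an 11-fold higher number from compound 1 to compound 3 (1.03 log units; beyond the scatter).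

The next compound is compound 4 `Cc1cc(Nc2cc(N3CCN(C)CC3)nc(Nc3cccc([N+](=O)[O-])c3)n2)n[nH]1`, which has nitro in place of methoxy on an aromatic carbon, meta to a large group (nitro in place of methoxy on an aromatic carbon). The same change reads as 3-methoxyphenyl to 3-nitrophenyl.

The most relevant precedent is an 11-fold higher number from compound 1 to compound 3 (1.03 log units; beyond the scatter), a large step that links 4-nitrophenyl with 3-methoxyphenyl. Run backwards, it points to a lower number for compound 4. The step of a 2.9-fold higher number from compound 1 to compound 2 (0.47 log units; beyond the scatter) also favours nitro over chloro, though only within the 4-substituted pair. Within the data shown here, no measured pair separates the group from its place on the ring, so the full size of the large step cannot be assumed. A step toward stronger inhibition, beyond the scatter but smaller than that precedent, is expected in this assay.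

The estimated change is a 4.3-fold lower number from compound 3 to compound 4 (0.63 log units; beyond the scatter). For compound 4 the expected value is 45 nM, with an estimated range of 15 nM to 130 nM.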

Compound 4, half-maximal inhibitory concentration: 26 nM
The estimate for compound 4 lay 1.7-fold (0.24 log units) above the measured number; the measured number falls inside the stated range.
By their numbers in this assay, from the lowest: compounds 1 and 4 (each within the scatter of the next); then compound 2; then compound 3.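

In this assay, the change from methoxy to nitro on an aromatic carbon, meta to a large group, gives a 7.4-fold lower number from compound 3 to compound 4 (0.87 log units; beyond the scatter) with the ring place held constant, a comparison the earlier compounds could not provide, so the group itself accounts for a shift beyond the scatter at this position. Moving from 4-nitrophenyl to 3-nitrophenyl gives a 1.4-fold higher number from compound 1 to compound 4 (0.16 log units; within the scatter) and so leaves no readable difference between the two nitro placements, while replacing 4-chlorophenyl with 3-nitrophenyl gives a 2.0-fold lower number from compound 2 to compound 4 (0.31 log units; beyond the scatter) and places this nitro compound ahead of the chloro compound, though only just beyond the scatter. Nothing available gives a measured reason for any of these steps.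

The compounds shown do not tell whether chloro, meta to a large group, would keep the number seen for the 4-chlorophenyl compound, so the group and its ring place remain separated only for nitro. Also open, on these data alone, is how an amine, a carboxylic acid or a nitrile at that same place would compare with nitro and methoxy on this read-out.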